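A few compounds are considered here, and "the series" means these few. Any claim that something is new, unique, unknown or untested is made for them only; others in the source may bear on it.

Compound 1 `Cc1ccc(C2=NN(c3ccc(S(C)(=O)=O)cc3)C(=O)CC2)cc1`: 1300 nM
Compound 2 `Cc1cc(O)ccc1C1=NN(c2ccc(S(C)(=O)=O)cc2)C(=O)CC1`: 9070 nM

In a functional assay on HOP-62 cells (Homo sapiens) for inhibition, read by sulforhodamine B assay, with a stated time of 48 h (on this read-out higher numbers stand for weaker inhibition of growth and lower numbers for stronger inhibition of growth), compound 2 has the higher number of the two, at 9070 nM. Compound 3 `CCc1ccc(C2=NN(c3ccc(S(C)(=O)=O)cc3)C(=O)CC2)cc1` differs from it as follows: 4-ethylphenyl in place of 4-hydroxy-2-methylphenyl on a carbon with a double bond to nitrogen. Going by the values given here, one measured step bears on this change: a 7.0-fold higher number from compound 1 to compound 2 (0.84 log units; beyond the scatter). That step introduced the 4-hydroxy-2-methylphenyl group, which compound 3 does not carry. Its 4-ethylphenyl group instead resembles the 4-methylphenyl group of compound 1, at 1300 nM. A similar-sized move toward a lower number, beyond the scatter, is therefore expected: a 6.0-fold lower number from compound 2 to compound 3 (0.78 log units; beyond the scatter). The estimate for compound 3 is 1500 nM, with an expected range of 500 nM to 4500 nM.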

Compound 3, concentration for 50% growth inhibition: 4300 nM
The estimate for compound 3 lay 2.9-fold (0.46 log units) below the measured number; the range from low to high includes it.
By their numbers in this assay, from the lowest: compound 1; then compound 3; then compound 2.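

In this assay, 4-ethylphenyl in place of 4-hydroxy-2-methylphenyl gives a real but small gain (a 2.1-fold lower number from compound 2 to compound 3 (0.32 log units; beyond the scatter)), so this swap recovers only part of the loss seen with the hydroxy-bearing group. The position is also sensitive to a very small change: going from 4-methylphenyl to 4-ethylphenyl weakens growth inhibition (a 3.3-fold higher number from compound 1 to compound 3 (0.52 log units; beyond the scatter)). No supporting data explain either step. Still open, as far as these compounds go, is how a longer chain, such as propyl, or an amine on this phenyl ring would read, and whether the hydroxy or the added methyl drives the number of compound 2.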